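The compounds below may be only part of what the source reports. "The series", "measured", "known", "first", "only" and "open" are said of these compounds alone.

Compound 2 `COc1ccc2[nH]c(C(=O)N3CC(=O)N(Cc4ccccc4)[C@@H](CCN4CCC5(CC4)CC5)C3)cc2c1` gives in a physicochemical assay for solubility, read by spectrophotometry, in phosphate buffer, with a stated time of 2 h, at pH 7.4 (a higher number here means a more soluble compound, a lower number a less soluble compound), only a limit, > 25000 nM; this is where compound 2 stands (the limit of > 25000 nM in this assay, at which 1 of the 2 values shown sits). Compound 1 `COc1ccc2[nH]c(C(=O)N3CC(=O)N(Cc4ccccc4)[C@@H](CN4CCC5(CC4)CC5)C3)cc2c1` gives in this assay 28200 nM. The step that the limit leaves unreadable from compound 1 to compound 2 is left unreadable by that limit. Compound 3 `COc1ccc2[nH]c(C(=O)N3CC(=O)N(Cc4ccccc4)[C@@H](Cc4ccccn4)C3)cc2c1` differs from compound 2 by a group of 6 heavy atoms (5 carbon, 1 nitrogen; one six-membered aromatic ring with 1 hetero atom) in place of a group of 9 heavy atoms (8 carbon, 1 nitrogen; one three-membered non-aromatic ring of carbon only, one six-membered non-aromatic ring with 1 hetero atom), on a saturated chain carbon bound to a saturated ring carbon. For the measured compounds named here, no measured step here has a readable size at the same place, so there is no basis for a direction beyond the scatter. The expected step is an at least 1.2-fold lower number from compound 2 to compound 3 (0.09 log units; that floor lies within the scatter), kept small. Compound 3 is estimated at 20000 nM, between 5000 nM and 50000 nM.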

Compound 3, solubility: > 100000 nM
Compound 3: only a limit was reported; the forecaster's own chance of this, stated with the estimate: 30%; middle value at least 5.0-fold (0.69 log units) from the limit.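

For the compounds shown here, at the saturated chain carbon bound to a saturated ring carbon, pyridin-2-yl gives the first readable step in this assay: an at least 3.5-fold higher number from compound 1 to compound 3 (0.54 log units; beyond the scatter). Compound 3 stands only as a limit, so that step gives a floor and not a full size: the limit of > 100000 nM in this assay, at which 1 of the 3 values shown sits. The steps from compound 1 to compound 2 and from compound 2 to compound 3 cannot be read.

Going by these compounds, how far the true value of compound 3 lies past its limit stays open. Also open, on these data alone, is whether a longer chain carrying pyridin-2-yl, or a phenyl group at this place, would give a step of similar size.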